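Carbamate in place of propyl at the hydroxyl-bearing chain

This account rests on a few compounds, and the source may have more. Where it says the series, first, only, none or still open, it means among the compounds named here.

Measured compounds:
compound 1 `CCCCCCCC(=O)OCC(O)Cn1cc(CN2CCN(c3ccccc3)CC2)nn1` gives 26%
compound 2 `CCCCC(O)Cn1cc(CN2CCN(c3ccccc3)CC2)nn1` gives 47%

For the measured compounds named here, in an assay on nucleic acid for inhibition of Nucleic Acid, read by fluorescence, tested at 100 uM (on this read-out higher numbers stand for more inhibition at the one concentration tested (going by the name of the read-out) and lower numbers for less inhibition), compound 2 gives 47% and stands highest of the two numbers known; its nearest neighbour is compound 1 with 26%. Going by the values given here, the only step known so far is a number 21 percentage points higher from compound 1 to compound 2 (beyond the scatter), a modest gain when propyl takes the place of (heptylcarbonyl)oxy on a saturated chain carbon, two bonds along the chain from an oxygen on a saturated carbon.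

Compound 3 `O=C(NCc1ccccc1)OCC(O)Cn1cc(CN2CCN(c3ccccc3)CC2)nn1` has not been measured. It differs from compound 2 by (benzylcarbamoyl)oxy in place of propyl on a saturated chain carbon, two bonds along the chain from an oxygen on a saturated carbon. This change runs in a direction opposite to the step from compound 1 to compound 2: an oxygen-linked carbonyl group again takes the place of propyl at the same position, so the relevant step is that one, and its size was modest. Among the compounds with values here, because of a number 21 percentage points higher from compound 1 to compound 2 (beyond the scatter) a drop in this assay is expected for compound 3, though the entering group is not the one that left in compound 1, so the size is uncertain. For compound 3 a step of a number 15 percentage points lower from compound 2 to compound 3 (beyond the scatter) is estimated, giving an expected value of 32% with a range from 15% to 50%.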

Compound 3, a percentage reported as inhibition, at one concentration (the size of the read-out at that concentration, not a potency): 32%
Compound 3: middle estimate and measured number agree at the digits printed; the measured number falls inside the stated range.
By their numbers in this assay, from the lowest: compounds 1 and 3 (each within the scatter of the next); then compound 2.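

In this assay the exchange of propyl for (benzylcarbamoyl)oxy gives a number 15 percentage points lower from compound 2 to compound 3 (beyond the scatter) and so shows that the lower number of compound 1 is not confined to its (heptylcarbonyl)oxy group: both compounds with an oxygen-linked carbonyl group on this saturated chain carbon, two bonds along the chain from an oxygen on a saturated carbon, stand below compound 2. The other new comparison, with benzylamino in place of heptyl on a carbonyl carbon, gives a number 6 percentage points higher from compound 1 to compound 3 (within the scatter) and does not separate the two compounds, even though the entering group brings a six-membered aromatic ring of carbon only and a hydrogen-bond donor. No other measurement here bears on the reason for these steps.

The three compounds leave open whether the linking carbonyl or the greater size of the entering groups goes with the lower numbers, since compound 2 alone carries a plain alkyl group here. A benzyl group joined directly to the chain, a longer alkyl chain or a primary amine at this place could help to separate those two readings.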